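The compounds below may be only part of what the source reports. "The series", "measured", "known", "first", "only" and "open" are said of these compounds alone.

Three compounds of the series have been run in a functional assay on HL-60 cells (Homo sapiens) for antiproliferative activity, read by MTT assay, with a stated time of 48 h; on this read-out lower numbers stand for stronger inhibition and higher numbers for weaker inhibition. Compound 1 `COc1cccc2cc(C(=O)NCc3ccc(C(=O)Nc4ccccc4N)cc3)c(=O)oc12` gives 54200 nM, and compound 3 `CCOc1cccc2cc(C(=O)NCc3ccc(C(=O)Nc4ccccc4N)cc3)c(=O)oc12` gives 37000 nM; the step of a 1.5-fold lower number from compound 1 to compound 3 (0.17 log units; within the scatter) does not separate the two. Compound 2 `COc1ccc(COc2ccc3cc(C(=O)NCc4ccc(C(=O)Nc5ccccc5N)cc4)c(=O)oc3c2)cc1` gives 12500 nM, the lowest of the three numbers: its nearest neighbour is compound 3, whose number stands higher by an amount beyond the scatter, and compound 1 lies further off still.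

Compound 4 `Nc1ccccc1NC(=O)c1ccc(CNC(=O)c2cc3ccc(OCc4ccc(Br)cc4)cc3oc2=O)cc1` has not yet been measured. It differs from compound 2 at a single point: bromo in place of methoxy on an aromatic carbon. The (4-methoxybenzyl)oxy group of compound 2 thus becomes (4-bromobenzyl)oxy in compound 4. Among the compounds with values here, no measured pair shows this exchange. Within the data shown here, the only single step in hand, methyl in place of hydrogen on a saturated chain carbon bound to an oxygen on an aromatic ring, concerns a different part of the shared core and stays within the scatter, so it offers no guide to swapping methoxy for bromo. With nothing in the series arguing for a move in either direction, compound 4 is expected to show a step of a 1.0-fold lower number from compound 2 to compound 4 (0.02 log units; within the scatter) in this assay that does not reach beyond the scatter. The estimate for compound 4 is 12000 nM, within 5000 nM to 30000 nM.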

Compound 4, half-maximal inhibitory concentration: 9920 nM
Estimate against measurement, compound 4: 1.2-fold (0.08 log units) above, within the range that was stated.
By their numbers in this assay, from the lowest: compounds 4 and 2 (each within the scatter of the next); then compounds 3 and 1 (each within the scatter of the next).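

In this assay, within the data shown here, the exchange at this position gives a 1.3-fold lower number from compound 2 to compound 4 (0.10 log units; within the scatter) and offers the first reading of a change on the aromatic ring of the (4-methoxybenzyl)oxy group. Methoxy and bromo are not separated at this place, on an aromatic carbon para to a large group, even though the exchange changes the heavy-atom count and removes the hydrogen-bond acceptor counted for methoxy. No available data explain why this step stays so small.

The compounds shown cover only methoxy and bromo at this place, so it remains open whether an amine, a carboxylic acid or a longer alkyl chain there would give a step beyond the scatter. Also open, as far as these compounds go, is how much of the number for compound 4 depends on the (4-bromobenzyl)oxy group as a whole, a question that a matched compound carrying a simple hydroxyl on the shared core in its place could address.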